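The compounds below may be only part of what the source reports. "The series", "measured", "known", "first", "only" and "open" are said of these compounds alone.

Measured compounds:
- compound 1, `CCOC(=O)c1cc(-c2cccc(OCc3ccccc3F)c2)on1`: "not determined" (no result reported)
- compound 2, `CCOC(=O)c1cc(-c2cccc(OCc3cccc(C(F)(F)F)c3F)c2)on1`: > 128000 nM

Compound 1, `CCOC(=O)c1cc(-c2cccc(OCc3ccccc3F)c2)on1`, carries no single number in an ADME assay on Vero cells (Chlorocebus sabaeus) for cytotoxicity, with a stated time of 72 h; on this read-out higher numbers stand for weaker inhibition and lower numbers for stronger inhibition; for compound 1 the result is "not determined" (no result reported). Compound 2, `CCOC(=O)c1cc(-c2cccc(OCc3cccc(C(F)(F)F)c3F)c2)on1`, reaches only a limit of the assay in this assay, > 128000 nM, and that limit is where one of the two values shown sits, see (the limit of > 128000 nM in this assay, at which 1 of the 2 values shown sits). Compound 3, `CCOC(=O)c1cc(-c2cccc(OCc3ccc(F)c(F)c3F)c2)on1`, is not yet measured. It differs from compound 1 as follows: 2,3,4-trifluorophenyl in place of 2-fluorophenyl on a saturated chain carbon bound to an oxygen on an aromatic ring. Within the data shown here, no step between measured compounds is available, so the size of the change in this assay cannot be read from the series; no shift beyond the usual scatter is expected, and a limit rather than a number seems the most likely outcome. Compound 3 is expected to come in near 160000 nM, with a range from 60000 nM to 450000 nM.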

Compound 3, half-maximal inhibitory concentration: > 128000 nM
Compound 3 gave a limit, no number; the forecaster's own chance of this, stated with the estimate: 80%; the middle value is on the limit's open side.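

No step can be read between compound 1 and compound 3. Compound 3 gives > 128000 nM in this assay, a limit and not a number. The compounds shown leave open whether 2,3,4-trifluorophenyl in place of 2-fluorophenyl changes this read-out at all: the limit of > 128000 nM in this assay, at which 2 of the 3 values shown sit.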